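The source may report more compounds than this note shows. Statements on the series, on what has been measured and on what is new or still open speak of the compounds shown alone.

In an assay on CHO cells for displacement of a labelled ligand from adenosine receptor A3 (Homo sapiens), read by scintillation counting, with a stated time of 60 min (on this read-out lower numbers stand for stronger inhibition and higher numbers for weaker inhibition), compound 1 `O=C(C/C=C/c1cccc(Cl)c1)Nc1nc2ccccc2c(=O)s1` gives only a limit, > 1000 nM. Compound 2 `O=C(CCc1ccccc1Br)Nc1nc2ccccc2c(=O)s1` likewise returns a limit, > 1000 nM. Compound 3 `O=C(CCCc1cccc(Cl)c1)Nc1nc2ccccc2c(=O)s1` also stops at a limit, > 1000 nM. Among the compounds with values here, the single one-place step within the set, a step that the two limits leave unreadable from compound 2 to compound 3, is therefore unreadable, and the limit of > 1000 nM in this assay, at which 3 of the 3 values shown sit, sums up the picture: every value recorded so far sits at that limit. Compound 4 `O=C(C/C=C/c1ccc(Cl)c(Cl)c1)Nc1nc2ccccc2c(=O)s1` differs from compound 1 by chloro in place of hydrogen on an aromatic carbon. Within the data shown here, no measured step bears on this change, and compound 1 itself offers no number to move from. For compound 4 the step that the limit leaves unreadable from compound 1 to compound 4 is expected, with a limit once more the likeliest outcome. Compound 4 is thus estimated at 3000 nM, within a range of 500 nM to 20000 nM.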

Compound 4, inhibition constant: > 1000 nM
Compound 4 gave a limit, no number; the forecaster's own chance of this, stated with the estimate: 75%; the middle value does not contradict the limit.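

Compound 1 and compound 4 both give only limits in this assay, so no step between them can be read: the limit of > 1000 nM in this assay, at which 4 of the 4 values shown sit.

The compounds shown leave open what values lie behind these limits and whether the added chloro changes anything.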